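Pyridinyl to Phenyl on a Cytotoxic Pyridine Scaffold

The source may hold more compounds than are shown below. What is called first, only, known or untested is meant among the compounds shown, and "the series" means these compounds.

Measured compounds:
compound 1 `Oc1ccc(-c2cc(-c3ccc(Cl)cc3)nc(-c3cccnc3)c2)cc1`, 22800 nM
compound 2 `Oc1cccc(-c2cc(-c3ccc(Cl)cc3)nc(-c3cccnc3)c2)c1`, 26800 nM
compound 3 `Oc1ccc(-c2cc(-c3cccnc3)nc(-c3cccc(Cl)c3)c2)cc1`, 22900 nM

In a functional assay on DU-145 cells (Homo sapiens) for cytotoxicity, read by CCK-8 assay and cell counting, with a stated time of 2 days (on this read-out higher numbers stand for weaker inhibition and lower numbers for stronger inhibition), compound 1 gives 22800 nM, the lowest of the three numbers, though compound 3 at 22900 nM and compound 2 at 26800 nM lie within the scatter of it. The two measured steps, a 1.2-fold higher number from compound 1 to compound 2 (0.07 log units; within the scatter) and a 1.0-fold higher number from compound 1 to compound 3 (0.00 log units; within the scatter), each move a substituent around one of the outer rings and leave the read-out essentially unchanged.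

Compound 4 `Oc1ccc(-c2cc(-c3ccccc3)nc(-c3ccc(Cl)cc3)c2)cc1` has not been measured. It differs from compound 1 by phenyl in place of pyridin-3-yl on an aromatic carbon. Going by the values given here, neither measured step touches this ring, so there is no direct precedent; what the data show is only that the rearrangements tried so far, compound 1 to compound 2 and compound 1 to compound 3, stayed within the scatter. On that basis the step of a 1.1-fold higher number from compound 1 to compound 4 (0.04 log units; within the scatter) is expected to be small, in no firm direction. Compound 4 is therefore estimated at 25000 nM, with a range from 10000 nM to 60000 nM.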

Compound 4, half-maximal inhibitory concentration: 7270 nM
Beside the measured number, compound 4's estimate is 3.4-fold (0.54 log units) above it, outside the stated range (below it).
By their numbers in this assay, from the lowest: compound 4; then compounds 1, 3 and 2 (each within the scatter of the next).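

In this assay, replacing pyridin-3-yl with phenyl next to the ring nitrogen of the core gives a 3.1-fold lower number from compound 1 to compound 4 (0.50 log units; beyond the scatter) and is the only step shown that lies beyond the scatter. The read-out therefore responds to this ring, whereas moving the hydroxyl or the chlorine on the outer rings left it essentially unchanged. The step is modest and rests on a single pair, in which the ring nitrogen of pyridin-3-yl is the only atom exchanged, but nothing measured here explains why this exchange shifts the number.

The compounds shown leave open whether a pyridin-4-yl, a cyclohexyl or a phenyl carrying an amine or a carboxylic acid at this position would give a lower or higher number. They also leave open whether moving the hydroxyl or the chlorine would remain as silent with phenyl in this place.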